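A few compounds are considered here, and "the series" means these few. Any claim that something is new, unique, unknown or untested is made for them only; others in the source may bear on it.

Working notes on the series. Compound 1 `CN(CCC(Oc1ccc(C(F)(F)F)cc1)c1ccc(F)cc1)CC(=O)O` carries a trifluoromethyl on the ether-linked aromatic ring and a fluoro on the other; in an assay on CHO cells for inhibition of sodium- and chloride-dependent glycine transporter 1 (Homo sapiens) (on this read-out higher numbers stand for weaker inhibition and lower numbers for stronger inhibition), compound 1 gives 251 nM. Compound 2 `CN(CC[C@@H](Oc1ccc(-c2ccccc2)cc1)c1ccccc1)CC(=O)O` differs in both aromatic rings and lacks the fluoro; in this assay compound 2 gives 151 nM, a number within the scatter of that for compound 1. Compound 3 `CN(CCCC(=O)O)CCC(Oc1ccc(C(F)(F)F)cc1)c1ccccc1` places the acid on a longer chain; in this assay compound 3 gives 100000 nM, which lies far beyond the scatter from compound 1. On the three numbers shown compound 1 therefore stands second highest, close to compound 2 and very far from compound 3.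

Compound 4 `CN(CCC(Oc1ccc(C(F)(F)F)cc1)c1ccc(Cl)cc1)CC(=O)O` has not been measured. Relative to compound 1 the change is chloro in place of fluoro on an aromatic carbon. For the measured compounds named here, no pair of measured compounds in this set shows the fluoro-to-chloro exchange, so its size here is unknown. The step from compound 1 to compound 4 in this assay is expected to be small, at most a slight move toward a lower number, with a 1.4-fold lower number from compound 1 to compound 4 (0.14 log units; within the scatter) as the expected size, within the scatter. Compound 4 is therefore expected to give 180 nM in this assay, with a range from 70 nM to 500 nM.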

Compound 4, half-maximal inhibitory concentration: 100 nM
Compound 4: the middle estimate sits 1.8-fold (0.26 log units) above what was measured, within the range that was stated.
By their numbers in this assay, from the lowest: compounds 4, 2 and 1 (each within the scatter of the next, the first and the last beyond it); then compound 3.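

In this assay the series now has its first readable single-place step: chloro in place of fluoro gives a 2.5-fold lower number from compound 1 to compound 4 (0.40 log units; beyond the scatter), a modest change. The substituent on this six-membered aromatic ring of carbon only, para to a large group, therefore affects the read-out, and on this one pair the 4-chlorophenyl compound gives the lower number. No supporting measurement bears on why the exchange has this effect, so the step stands as an observation only.

For the compounds shown here, the single pair leaves open whether a bromo, a methyl or a methoxy at this place would extend the step or reverse it, and whether the same exchange would give a similar step with the biphenyl-type ether of compound 2 or with a longer acid chain. The remaining pairs differ in more than one place, so their steps cannot be read, and the contribution of the longer chain in compound 3 cannot be separated from the absence of the halogen.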